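Chloro in Place of Methyl: Expectations for Compound 4

The compounds below may be only part of what the source reports. "The series", "measured", "known", "first", "only" and "open" are said of these compounds alone.

Compound 3 `Cc1ccc(Nc2sc(C(=O)c3ccc(C)cc3)c(C)c2C(=O)O)cc1` is recorded in a functional assay, with a stated time of 150 min, tested at 5 ug/mL (a lower number here means a weaker effect, a higher number a stronger effect of the compound at the concentration tested), only as "not active" (no number reported), with no single number to place it, and compound 1 `COC(=O)c1c(Nc2ccc(Cl)cc2)sc(C(=O)c2ccc(C)cc2)c1C` likewise stands at "not active" (no number reported) in this assay. Compound 2 `Cc1ccc(C(=O)c2sc(Nc3ccccc3)c(C(=O)O)c2C)cc1` gives 0.26% in this assay, a read-out close to zero. Compound 4 `Cc1ccc(C(=O)c2sc(Nc3ccc(Cl)cc3)c(C(=O)O)c2C)cc1` differs from compound 3 in one place: chloro in place of methyl on an aromatic carbon. The (4-methylphenyl)amino group becomes a (4-chlorophenyl)amino group. Within the data shown here, no measured pair shows this change, so its size is unknown from the data; the step from compound 3 to compound 4 in this assay is expected to be none beyond the scatter, because compound 2 gives 0.26%. Compound 4 is therefore expected to give 1%, within 0% to 10%.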

Compound 4, a percentage reported as activity, at one concentration (the size of the read-out at that concentration, not a potency): "not active" (no number reported)
No number was reported for compound 4; no gap can be computed for the estimate.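

In this assay compound 3 stands at "not active" (no number reported) and compound 4 at "not active" (no number reported), so no step can be read between them. The compounds shown leave open what chloro in place of methyl does to the read-out. No evidence bears on this result.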